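A few compounds are considered here, and "the series" means these few. Any claim that something is new, unique, unknown or untested is made for them only; others in the source may bear on it.

In a functional assay on the whole organism (strain C57B/6) with Mus musculus as the target, in the maximal electroshock model (on this read-out higher numbers stand for an effect only at larger amounts of compound and lower numbers for an effect already at smaller amounts), compound 1, `CCCCCCCc1nncn1-c1ccc(OCCCCCC)cc1`, gives only a limit of > 40 mg/kg. Compound 1 thus sits at the limit of > 40 mg/kg in this assay, at which 1 of the 2 values shown sits. Compound 2, `CCCCCCOc1ccc(-n2cnnc2-c2ccccc2F)cc1`, gives 20.2 mg/kg in this assay, the only number shown. Among the compounds with values here, the single measured step is an at least 1.9-fold lower number from compound 1 to compound 2 (0.29 log units; that floor lies within the scatter), and it concerns an alkyl-for-aryl exchange, not the aryl group itself. Compound 3, `CCCCCCOc1ccc(-n2cnnc2-c2ccc(Cl)cc2)cc1`, differs from compound 2 by 4-chlorophenyl in place of 2-fluorophenyl on an aromatic carbon. Within the data shown here, no measured step bears on this exchange, so the expected step of a 1.0-fold lower number from compound 2 to compound 3 (0.00 log units; within the scatter) is none beyond the scatter. Compound 3 is estimated to give 20 mg/kg, between 8 mg/kg and 50 mg/kg.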

Compound 3, dose for half-maximal effect: 19.7 mg/kg
Estimate against measurement, compound 3: 1.0-fold (0.01 log units) above, and the stated range covers the measured number.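

The exchange on this aromatic carbon of the five-membered ring gives a 1.0-fold lower number from compound 2 to compound 3 (0.01 log units; within the scatter), so in this assay 4-chlorophenyl and 2-fluorophenyl cannot be told apart here. With heptyl replaced by 4-chlorophenyl, the result is an at least 2.0-fold lower number from compound 1 to compound 3 (0.30 log units; that floor lies within the scatter), so this aryl group, like 2-fluorophenyl, is not shown to differ from heptyl beyond the scatter. Compound 1 remains a limit and not a number: the limit of > 40 mg/kg in this assay, at which 1 of the 3 values shown sits.

As far as these compounds go, whether a pyridyl ring or a 4-methoxyphenyl group on this carbon would give a number apart from these two stays open. So does the actual distance between heptyl and the aryl groups.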